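The source may report more compounds than this note shows. Statements on the series, on what has been measured and on what is new or still open speak of the compounds shown alone.

Three compounds were measured in a functional assay, read by Griess assay, with a stated time of 2.5 h; a lower number here means a stronger inhibitor, a higher number a weaker inhibitor. Compound 1 `COc1cc(OC)c(-c2cc(=O)c3cc(O)ccc3o2)cc1OC` gives 2.14 ug/mL, compound 2 `COc1cc(OC)c(OC)cc1/C=C/C(=O)c1ccc(O)cc1O` gives 2.76 ug/mL, and compound 3 `COc1cc(OC)c(-c2cc(=O)c3ccc(O)cc3o2)cc1OC` gives 2.27 ug/mL. Compound 2 has the highest of the three numbers, but its gaps to compound 3 and to compound 1 both lie within the scatter, so the three compounds cannot be ranked against one another. Compound 4 `COc1cc(OC)c(OC)cc1/C=C/C(=O)c1ccc(Cl)cc1` has not yet been measured; it differs from compound 2 by 4-chlorophenyl in place of 2,4-dihydroxyphenyl on a carbonyl carbon. Among the compounds with values here, no measured pair shows this change, so its effect is not known from these data; a modest weakening is expected in this assay, a step of a 1.8-fold higher number from compound 2 to compound 4 (0.26 log units; within the scatter). Compound 4 is therefore estimated at 5 ug/mL, with a range from 1.5 ug/mL to 20 ug/mL.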

Compound 4, half-maximal inhibitory concentration: 2.01 ug/mL
Compound 4: middle estimate off by 2.5-fold (0.40 log units), on the high side; measured number inside the range.
By their numbers in this assay, from the lowest: compounds 4, 1, 3 and 2 (each within the scatter of the next).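

In this assay, 4-chlorophenyl in place of 2,4-dihydroxyphenyl on a carbonyl carbon gives a 1.4-fold lower number from compound 2 to compound 4 (0.14 log units; within the scatter). This position therefore accepts an aryl group with 0 hydrogen-bond donors and 0 hydrogen-bond acceptors without a change that can be told from the scatter, so in this pair the hydroxy groups are not needed to hold the number at this level. Nothing measured here explains this tolerance. As far as these compounds go, whether an aminophenyl or carboxyphenyl group on that carbonyl carbon would hold the number remains open. From the compounds shown here alone, the separate contributions of the chlorine and of each hydroxy group also remain open.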